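This account rests on a few compounds, and the source may have more. Where it says the series, first, only, none or still open, it means among the compounds named here.

Compound 2 `CN(C)CCn1cnnc1-c1cc(Oc2ccc(NC(=O)N/N=C/c3ccc(O)c(Br)c3)cc2F)ccn1` has the smallest number among the three measured compounds in a functional assay on HT-29 cells (Homo sapiens) for cytotoxicity, read by MTT assay, with a stated time of 72 h; on this read-out higher numbers stand for weaker inhibition and lower numbers for stronger inhibition: compound 2 gives 450 nM. Compound 1 `CN(C)CCn1cnnc1-c1cc(Oc2ccc(NC(=O)N/N=C/c3cc(C(C)(C)C)cc(C(C)(C)C)c3O)cc2F)ccn1` gives 680 nM, a gap within the scatter, so no order between the two can be claimed. Compound 3 `Cn1ncnc1-c1cc(Oc2ccc(NC(=O)N/N=C/c3ccccc3)cc2F)ccn1` gives 30200 nM, far beyond the scatter from both. Compound 4 `CN(C)CCn1cnnc1-c1cc(Oc2ccc(NC(=O)N/N=C/c3ccc(O)c(O)c3)cc2F)ccn1` differs from compound 2 by hydroxy in place of bromo on an aromatic carbon. Among the compounds with values here, no measured pair shows this change, so its effect is unknown. Compound 1 shows that a differently substituted phenol keeps a similar number, so a modest weakening at most is expected. Compound 4 is expected to give 900 nM, in a range from 300 nM to 3000 nM. This corresponds to an expected step of a 2.0-fold higher number from compound 2 to compound 4 (0.30 log units; within the scatter).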

Compound 4, half-maximal inhibitory concentration: 1890 nM
Beside the measured number, compound 4's estimate is 2.1-fold (0.32 log units) below it; the measured number falls inside the stated range.
By their numbers in this assay, from the lowest: compounds 2 and 1 (each within the scatter of the next); then compound 4; then compound 3.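

In this assay the change from 3-bromo-4-hydroxyphenyl to 3,4-dihydroxyphenyl gives a 4.2-fold higher number from compound 2 to compound 4 (0.62 log units; beyond the scatter), which is the only measured view of this position. It shows that, on this core, hydroxy does not stand in for bromo without a weakening beyond the scatter, although the step remains modest. No available evidence accounts for this step.

From the compounds shown here alone, whether chloro, methoxy or an amine at this place would stay closer to compound 2 remains open. Also open, going by these compounds, is whether the same change would have a similar effect on another core.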